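A few compounds are considered here, and "the series" means these few. Any claim that something is new, unique, unknown or untested is made for them only; others in the source may bear on it.

Measured compounds in an ADME assay on PBMC cells (Homo sapiens) for cytotoxicity, read by CellTiter-Glo, with a stated time of 48 h (a higher number here means that more compound is needed for the effect, a lower number that less compound is needed), all three values being limits of the assay:

Compound 1 `CC(=O)N1CCN(c2ccc(CN(C3CCC3)S(=O)(=O)c3ccccc3)c(F)c2)CC1`: > 20000 nM.
Compound 2 `CC(=O)N1CCN(c2ccc(CN(C3CCC3)S(=O)(=O)Cc3ccccc3)c(F)c2)CC1`: > 20000 nM.
Compound 3 `CC(=O)N1CCN(c2ccc(CN(C3CCC3)S(=O)(=O)c3ccccc3F)c(F)c2)CC1`: > 20000 nM.

Compound 3 stands at a limit and has no numerical value: > 20000 nM. Among the measured compounds shown here, the series so far shows the same picture: the limit of > 20000 nM in this assay, at which 3 of the 3 values shown sit.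

The next compound is compound 4 `CC(=O)N1CCN(c2ccc(CN(C3CCC3)S(=O)(=O)Cc3ccccc3F)c(F)c2)CC1`. The change is 2-fluorobenzyl in place of 2-fluorophenyl on a sulfonyl sulfur, which is 2-fluorobenzyl in place of 2-fluorophenyl on a sulfonyl sulfur.

For the measured compounds named here, the closest precedent is the same exchange without the fluoro group, benzyl in place of phenyl on a sulfonyl sulfur: a step that the two limits leave unreadable from compound 1 to compound 2. The fluoro exchange gives a step that the two limits leave unreadable from compound 1 to compound 3. The remaining measured pair gives a step that the two limits leave unreadable from compound 2 to compound 3. None of these steps has a readable size, and none gives a direction.

Compound 2 already carries benzyl on the sulfonyl sulfur and reads > 20000 nM, again a limit. No step beyond the scatter is therefore expected in this assay, and the most likely report is another limit.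

The expected step is a number no higher from compound 3 to compound 4 (the limit leaves the size open). For compound 4 the estimate is 20000 nM, with an expected range of 12000 nM to 40000 nM.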

Compound 4, half-maximal effective concentration: > 20000 nM
Compound 4 was reported as a limit (the forecaster's own chance of this, stated with the estimate: 90%); the middle value lies on the limit itself.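

In this assay compound 4 gives > 20000 nM, which is a limit of the assay. Its steps from compound 1, compound 2 and compound 3 cannot be read. The compounds shown leave open where any true half-maximal value lies and whether the exchanges on the sulfonyl sulfur change it at all: the limit of > 20000 nM in this assay, at which 4 of the 4 values shown sit.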